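Swapping Trifluoromethoxy for Methylcarbamoyl on a Shared Core

The source may hold more compounds than are shown below. What is called first, only, known or untested is meant among the compounds shown, and "the series" means these compounds.

Compound 1, `CNc1nc(NCc2ccc(OC(F)(F)F)cc2)cc(-c2ccccn2)n1`, gives 7 nM.
Compound 2, `c1ccc(-c2cc(NCC3CC3)ncn2)nc1`, gives 10000 nM.
Compound 3, `CNc1nc(NCC2CCCCC2)cc(-c2ccccn2)n1`, gives 10 nM.

These three compounds have been tested in a functional assay on HEK293 cells for agonist activity at G-protein coupled receptor 39 (Mus musculus), read by inositol phosphate accumulation; on this read-out higher numbers stand for an effect only at larger amounts of compound and lower numbers for an effect already at smaller amounts. Compound 1 shows the lowest number of the three, but compound 3 sits close enough that the two cannot be told apart within the scatter, while compound 2 lies far away with a much higher number.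

Compound 4, `CNC(=O)c1ccc(CNc2cc(-c3ccccn3)nc(NC)n2)cc1`, differs from compound 1 in one place: methylcarbamoyl in place of trifluoromethoxy on an aromatic carbon. Going by the values given here, no pair of measured compounds isolates this change, so its effect is not known. Among the compounds with values here, in the one comparison available, compound 3 gives 10 nM with a quite different group in the varied part of the molecule, which suggests that part tolerates change. The step from compound 1 to compound 4 is therefore expected to be modest, a 4.3-fold higher number from compound 1 to compound 4 (0.63 log units; beyond the scatter), towards a higher number. Compound 4 is estimated at 30 nM, with a range from 5 nM to 300 nM.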

Compound 4, half-maximal effective concentration: 8 nM
Compound 4: the middle estimate sits 3.8-fold (0.57 log units) above what was measured, within the range that was stated.
By their numbers in this assay, from the lowest: compounds 1, 4 and 3 (each within the scatter of the next); then compound 2.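

In this assay putting methylcarbamoyl in place of trifluoromethoxy on the aromatic carbon gives a 1.1-fold higher number from compound 1 to compound 4 (0.06 log units; within the scatter) so the two groups cannot be told apart at this position. For this pair, the position accepts a group with one hydrogen-bond donor and a double bond outside aromatic rings in place of a group with no hydrogen-bond donor and three fluorines. No measured evidence accounts for this result. From the compounds shown here alone, whether a carboxylic acid or an amine at this place would fit as well remains open. Also open, going by these compounds, is whether the amide hydrogen matters, which dimethylcarbamoyl would help to test.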